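Sulfonamide-linked diamines: swapping nitro for methyl

The compounds below may be only part of what the source reports. "The series", "measured", "known", "first", "only" and "open" are said of these compounds alone.

Measured compounds:
Compound 1, `O=S(=O)(NCCNCc1cccc2ccccc12)c1cc(C(F)(F)F)cc(C(F)(F)F)c1`: 26000 nM
Compound 2, `O=[N+]([O-])c1ccc(S(=O)(=O)NCCCCCCNCc2ccc(Br)cc2)cc1`: 9800 nM

In a functional assay on MIA PaCa-2 cells (Homo sapiens) for inhibition, read by MTT assay, with a stated time of 72 h (a higher number here means a weaker inhibitor of growth, a lower number a stronger inhibitor of growth), compound 2 gives 9800 nM, the lowest of the two numbers; compound 1 sits at a higher number beyond the scatter. Compound 3, `Cc1ccc(S(=O)(=O)NCCCCCCNCc2ccc(Br)cc2)cc1`, has not yet been measured. It differs from compound 2 by methyl in place of nitro on an aromatic carbon. Among the compounds with values here, with no measured step of this kind available, the expectation rests only on compound 2 and the nature of the change: a small step, toward a higher number if anything, and likely within the scatter. Compound 3 is therefore estimated at 13000 nM, with a range of 4500 nM to 40000 nM, corresponding to an expected step of a 1.3-fold higher number from compound 2 to compound 3 (0.12 log units; within the scatter).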

Compound 3, concentration for 50% growth inhibition: 12300 nM
Compound 3: middle estimate off by 1.1-fold (0.02 log units), on the high side; measured number inside the range.
By their numbers in this assay, from the lowest: compounds 2 and 3 (each within the scatter of the next); then compound 1.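

In this assay, 4-nitrophenyl gives way to 4-methylphenyl with a 1.3-fold higher number from compound 2 to compound 3 (0.10 log units; within the scatter). At this carbon, para to a large group, the nitro group with its two hydrogen-bond acceptors can therefore be replaced by methyl, which has none, with no difference beyond the scatter. Nothing available explains why these two groups read alike.

On these data alone, whether an amine or a carboxylic acid at this position would read like nitro and methyl stays open. As far as these compounds go, it also stays open whether methyl and nitro would read alike on the core of compound 1.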